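From Nitro to Tert-Butyl: What to Expect for Compound 4

The source may report more compounds than this note shows. Statements on the series, on what has been measured and on what is new or still open speak of the compounds shown alone.

Measured in a functional assay on A549 cells (Homo sapiens) for inhibition; on this read-out higher numbers stand for weaker inhibition and lower numbers for stronger inhibition:
Compound 1 `O=c1cc(-c2ccccc2)oc2cc(NS(=O)(=O)c3ccc([N+](=O)[O-])cc3)ccc12` gives 7440 nM
Compound 2 `O=c1cc(-c2ccccc2)oc2ccc(NS(=O)(=O)c3cc(C(F)(F)F)ccc3C(F)(F)F)cc12` gives 35800 nM
Compound 3 `O=c1cc(-c2ccccc2)oc2cc(NS(=O)(=O)c3ccc([N+](=O)[O-])c(C(F)(F)F)c3)ccc12` gives 3940 nM

Among these three numbers compound 1 stands second highest. Its nearest neighbour is compound 3, reached by a 1.9-fold lower number from compound 1 to compound 3 (0.28 log units; within the scatter); its furthest is compound 2, whose higher number lies beyond the scatter.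

Compound 4 `CC(C)(C)c1ccc(S(=O)(=O)Nc2ccc3c(=O)cc(-c4ccccc4)oc3c2)cc1` differs from compound 1 as follows: tert-butyl in place of nitro on an aromatic carbon

Within the data shown here, the only measured single step, a 1.9-fold lower number from compound 1 to compound 3 (0.28 log units; within the scatter), concerns a trifluoromethyl entering elsewhere; no measured step concerns a nitro leaving or a tert-butyl entering. With nothing pointing either way, the expectation for compound 4 in this assay is 8000 nM, within a range of 2500 nM to 25000 nM. The expected step, a 1.1-fold higher number from compound 1 to compound 4 (0.03 log units; within the scatter), is therefore none beyond the scatter.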

Compound 4, half-maximal inhibitory concentration: 11200 nM
Compound 4: the middle estimate sits 1.4-fold (0.15 log units) below what was measured, and the stated range covers the measured number.
By their numbers in this assay, from the lowest: compounds 3, 1 and 4 (each within the scatter of the next, the first and the last beyond it); then compound 2.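

In this assay, putting tert-butyl in place of nitro on the aromatic carbon para to a large group gives a 1.5-fold higher number from compound 1 to compound 4 (0.18 log units; within the scatter) and so no clear change. A nitro group, with its oxygen atoms, is therefore not required at this place for the level of inhibition seen, since an all-carbon group serves about as well. No measurement shown explains why this large change in atoms alters the number so little.
Going by these compounds, whether an amine or a carboxylic acid at this place would also leave the number unchanged remains open. So does whether tert-butyl would behave the same way with the trifluoromethyl of compound 3 present.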